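This account rests on a few compounds, and the source may have more. Where it says the series, first, only, none or still open, it means among the compounds named here.

Measured so far in a functional assay on A549 cells (Homo sapiens) for antiproliferative activity, read by MTT assay, with a stated time of 72 h; on this read-out lower numbers stand for stronger inhibition and higher numbers for weaker inhibition:
- Compound 1, `COc1ccccc1-c1ccc2ncn(-c3cc(OC)c(OC)c(OC)c3)c2c1`: 4320 nM
- Compound 2, `COc1cc(-n2cnc3ccc(-c4ccc([N+](=O)[O-])cc4)cc32)cc(OC)c1OC`: 8940 nM
- Compound 3, `COc1cc(-n2cnc3ccc(-c4cccc(C)c4)cc32)cc(OC)c1OC`: 3820 nM

Compound 3 gives the lowest of the three numbers, but the gap is only a 1.1-fold lower number from compound 1 to compound 3 (0.05 log units; within the scatter), which is within the scatter, so compound 1 and compound 3 cannot be ordered. Only compound 2 is set apart: a 2.1-fold higher number from compound 1 to compound 2 (0.32 log units; beyond the scatter) and a 2.3-fold lower number from compound 2 to compound 3 (0.37 log units; beyond the scatter) are both beyond the scatter, so the 4-nitrophenyl compound is weaker than either of the other two aryl variants.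

The next compound is compound 4, `COc1cc(-n2cnc3ccc(-c4ccc(F)cc4)cc32)cc(OC)c1OC`. Its change from compound 3: 4-fluorophenyl in place of 3-methylphenyl on an aromatic carbon. All three measured steps vary the same aryl group and bear on this step, but none introduces a fluorine; the one substituent para to the fused ring seen so far, the 4-nitrophenyl of compound 2, gave a modest worsening, while swapping 2-methoxyphenyl for 3-methylphenyl gave a 1.1-fold lower number from compound 1 to compound 3 (0.05 log units; within the scatter). The expected step is therefore a 1.2-fold higher number from compound 3 to compound 4 (0.07 log units; within the scatter), which stays within the scatter. Compound 4 is estimated at 4500 nM, range 2200 nM to 9500 nM.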

Compound 4, half-maximal inhibitory concentration: 6740 nM
Estimate against measurement, compound 4: 1.5-fold (0.18 log units) below, and the stated range covers the measured number.
By their numbers in this assay, from the lowest: compounds 3, 1, 4 and 2 (each within the scatter of the next, the first and the last beyond it).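

In this assay, fluoro in place of nitro on the aryl ring gives a 1.3-fold lower number from compound 2 to compound 4 (0.12 log units; within the scatter), so the two groups cannot be told apart at this position. The other two steps, a 1.8-fold higher number from compound 3 to compound 4 (0.25 log units; within the scatter) and a 1.6-fold higher number from compound 1 to compound 4 (0.19 log units; within the scatter), also lie within the scatter, so compound 4 cannot be ordered against any of the three earlier aryl variants, and it bridges the gap that set compound 2 apart from compound 1 and compound 3. No measurement at hand explains where any of these numbers falls.

As far as these compounds go, all four compounds carry a substituted phenyl on this aromatic carbon, so the effect of an amine, a carboxylic acid or a longer alkyl chain on that ring remains open. From the compounds shown here alone, whether the gaps around compound 2 hold in any other cell line also remains open.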